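Pyridin-3-yl for 2-Fluorophenyl on a Nitroimidazole Oxadiazole

The source may report more compounds than this note shows. Statements on the series, on what has been measured and on what is new or still open speak of the compounds shown alone.

Measured compounds:
compound 1 `CCOc1ccc(-c2nnc(SCCn3c([N+](=O)[O-])cnc3C)o2)cc1` gives 16600 nM
compound 2 `Cc1ncc([N+](=O)[O-])n1CCSc1nnc(-c2ccccc2F)o1` gives 20500 nM
compound 3 `COc1cc(OC)cc(-c2nnc(SCCn3c([N+](=O)[O-])cnc3C)o2)c1` gives 12800 nM

All three were tested in a functional assay on MCF7 cells (Homo sapiens) for cytotoxicity, read by MTT assay, with a stated time of 48 h; on this read-out higher numbers stand for weaker inhibition and lower numbers for stronger inhibition. Compound 2 carries a 2-fluorophenyl group on the shared core and gives the nominally largest number of the three, yet its gaps to compound 1 and to compound 3 both fall within the usual scatter, so the three cannot be told apart on these numbers. Within the data shown here, no pair among them differs in only one place, so no single structural step has been measured.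

Compound 4 `Cc1ncc([N+](=O)[O-])n1CCSc1nnc(-c2cccnc2)o1` has not yet been tested. It differs from compound 2 in one place: pyridin-3-yl in place of 2-fluorophenyl on an aromatic carbon. Since nothing in the measured set shows how this kind of exchange moves the read-out, and since the three measured values sit together, compound 4 is expected to stay close to compound 2, with a step of a 1.0-fold lower number from compound 2 to compound 4 (0.01 log units; within the scatter) that is not expected to exceed the scatter. Compound 4 is therefore estimated at 20000 nM, within a range from 8000 nM to 50000 nM.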

Compound 4, half-maximal inhibitory concentration: 28700 nM
Beside the measured number, compound 4's estimate is 1.4-fold (0.16 log units) below it; the range from low to high includes it.
By their numbers in this assay, from the lowest: compounds 3, 1, 2 and 4 (each within the scatter of the next, the first and the last beyond it).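

In this assay, the exchange on the aromatic carbon of the five-membered ring gives a 1.4-fold higher number from compound 2 to compound 4 (0.15 log units; within the scatter), the first single-place step available for this series. At this position, then, pyridin-3-yl, with its ring nitrogen and hydrogen-bond acceptor, can stand in place of 2-fluorophenyl without a change that can be told from the scatter. Nothing at hand bears on how either group acts at this position.

This single step leaves open whether any other group at this position, such as an amine, a carboxylic acid or a longer chain, would move the read-out beyond the scatter. From the compounds shown here alone, it also remains open whether pyridin-3-yl would behave the same way in this assay on a different core, or whether the ring nitrogen would matter if placed elsewhere in that ring.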